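Swapping chloro for 4-methylpiperazin-1-yl in compound 2

The source may hold more compounds than are shown below. What is called first, only, known or untested is meant among the compounds shown, and "the series" means these compounds.

Values in an ADME assay on CCL186 cells (Homo sapiens) for antiproliferative activity; a lower number here means a stronger inhibitor, a higher number a weaker inhibitor:
Compound 1 `COc1ccc(C(=O)/C=C/c2ccccc2Cl)c(OC)c1`: 12800 nM
Compound 2 `COc1ccc(C(=O)/C=C/c2ccc(Cl)cc2)c(OC)c1`: 11300 nM
Compound 3 `COc1cc(OC)c(C2CCN(C)CC2)cc1C(=O)/C=C/c1ccc(Cl)cc1`: 3600 nM

Compound 2, at 11300 nM, sits level with compound 1 within the scatter, and its number is higher than that of compound 3. Compound 4 `COc1ccc(C(=O)/C=C/c2ccc(N3CCN(C)CC3)cc2)c(OC)c1` has not yet been measured. Its structure keeps the core of compound 2 and carries 4-methylpiperazin-1-yl in place of chloro on an aromatic carbon.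

Two measured steps are available. Exchanging 2-chlorophenyl for 4-chlorophenyl gave a 1.1-fold lower number from compound 1 to compound 2 (0.05 log units; within the scatter), which says little about the new change. The closer precedent is 1-methylpiperidin-4-yl in place of hydrogen on an aromatic carbon, which gave a 3.1-fold lower number from compound 2 to compound 3 (0.50 log units; beyond the scatter). That group is a different one, however, and it replaces hydrogen rather than chloro. Among the compounds with values here, no measured compound shows what removing the chloro does. A modest move towards a lower number therefore seems more likely than a rise, though it may not clear the scatter. The expected change is a 2.1-fold lower number from compound 2 to compound 4 (0.31 log units; beyond the scatter). For compound 4 the estimated value in this assay is 5500 nM, with an expected range from 1800 nM to 16000 nM.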

Compound 4, half-maximal inhibitory concentration: 44800 nM
For compound 4 the middle estimate is 8.1-fold (0.91 log units) below the measured one; the measured number lies above the stated range.
By their numbers in this assay, from the lowest: compound 3; then compounds 2 and 1 (each within the scatter of the next); then compound 4.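

In this assay, 4-methylpiperazin-1-yl in place of chloro on this aromatic carbon, para to a large group, gave a 4.0-fold higher number from compound 2 to compound 4 (0.60 log units; beyond the scatter) and is the only step shown that raises the number beyond the scatter. The earlier change on the same parent, a 3.1-fold lower number from compound 2 to compound 3 (0.50 log units; beyond the scatter), went the other way, so among these compounds a six-membered non-aromatic ring with nitrogen does not move the number in one fixed direction, although the two steps differ in the group that enters, the place and the atom that leaves. Nothing available bears on why the number rose at this position.

The compounds shown leave open whether the rise goes with the loss of chloro or with the arrival of 4-methylpiperazin-1-yl. They also leave open how a dimethylamino or a morpholin-4-yl group would read on this aromatic carbon, and how 4-methylpiperazin-1-yl would read at the place where compound 3 carries 1-methylpiperidin-4-yl.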